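The compounds below may be only part of what the source reports. "The series", "measured", "known", "first", "only" and "open" are said of these compounds alone.

Measured so far in an ADME assay on microsomes from liver (Mus musculus) for pharmacokinetics, read by LC-MS, using NADPH, with stated times of 5 min, 15 min and 30 min, tested at 10 uM; on this read-out higher numbers stand for fast clearance and lower numbers for slow clearance:
compound 1 `C[C@H](NC(=O)c1ncccn1)c1ccc(NC(=O)N2CC(c3cccnc3)C2)cc1`: 28.9 mL.min-1.g-1
compound 2 `C[C@@H](c1ccc(NC(=O)N2CC(c3cncc(N)c3)C2)cc1)N1Cc2ccccc2C1=O`: 158 mL.min-1.g-1

Compound 2, at 158 mL.min-1.g-1, holds the higher of the two numbers, and its gap to compound 1 lies beyond the usual scatter. Going by the values given here, no step between measured compounds that differ in one place is available, so the two values show only that gap.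

Compound 3 `C[C@H](NC(=O)c1ncccn1)c1ccc(NC(=O)N2CC(c3cncc(N)c3)C2)cc1` departs from compound 2 in one place: a group of 9 heavy atoms (5 carbon, 3 nitrogen, 1 oxygen; one six-membered aromatic ring with 2 hetero atoms) in place of a group of 10 heavy atoms (8 carbon, 1 nitrogen, 1 oxygen; one five-membered non-aromatic ring with 1 hetero atom, one six-membered aromatic ring of carbon only), on a saturated chain carbon bound to an aromatic carbon and a saturated chain carbon. The entering ((pyrimidin-2-yl)carbonyl)amino group is already present in compound 1, which gives 28.9 mL.min-1.g-1 in this assay. On that single comparison, a drop beyond the scatter is expected, toward slower clearance. The expected step is a 4.5-fold lower number from compound 2 to compound 3 (0.65 log units; beyond the scatter). For compound 3 the estimated value is 35 mL.min-1.g-1, with an expected range of 15 mL.min-1.g-1 to 85 mL.min-1.g-1.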

Compound 3, intrinsic clearance in microsomes: 83.4 mL.min-1.g-1
Beside the measured number, compound 3's estimate is 2.4-fold (0.38 log units) below it; the measured number falls inside the stated range.
By their numbers in this assay, from the lowest: compound 1; then compounds 3 and 2 (each within the scatter of the next).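

In this assay, putting ((pyrimidin-2-yl)carbonyl)amino on the saturated chain carbon bound to an aromatic carbon and a saturated chain carbon, in place of the group carried by compound 2, gives a 1.9-fold lower number from compound 2 to compound 3 (0.28 log units; within the scatter), so this exchange does not separate the two compounds on intrinsic clearance. Going by these compounds alone, with ((pyrimidin-2-yl)carbonyl)amino held constant, amino in place of hydrogen on an aromatic carbon gives a 2.9-fold higher number from compound 1 to compound 3 (0.46 log units; beyond the scatter), the only single-place step here that lies beyond the scatter. Nothing at hand accounts for either step.

On these data alone, it remains open whether a methoxy group or a fluorine atom in place of that amino group would give a step of similar size. As far as these compounds go, the size of the amino step with the group of compound 2 on the saturated chain carbon also remains open.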